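The compounds below may be only part of what the source reports. "The series", "measured", "known", "first", "only" and "open" are said of these compounds alone.

Measured compounds:
- compound 1, `COc1ccc(N2C(=O)COc3ccc(-c4cnc5ccccc5c4)cc32)cc1`: > 40000 nM
- compound 2, `COc1ccc(N2C(=O)COc3ccc(-c4cnc(OC)c(NS(=O)(=O)c5ccc(F)cc5)c4)cc32)cc1`: 18400 nM

The measurement in question is a functional assay on A-375 cells (Homo sapiens) for antiproliferative activity, read by MTT assay, with a stated time of 72 h; on this read-out higher numbers stand for weaker inhibition and lower numbers for stronger inhibition. In this assay compound 1 gives > 40000 nM, which is a limit of the assay and not a number; compound 1 stands at the limit of > 40000 nM in this assay, at which 1 of the 2 values shown sits. Compound 2 gives 18400 nM, a measured number, and no step between compound 1 and compound 2 is computed here, so the two values are only shown side by side.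

Compound 3, `O=C1COc2ccc(-c3cnc4ccccc4c3)cc2N1c1ccccc1`, has not yet been measured. It differs from compound 1 by hydrogen in place of methoxy on an aromatic carbon. The change removes a small group from the shared core of compound 1 and leaves everything else in place.

Within the data shown here, since compound 1 gives only a limit in this assay, there is no number from which a step could be reckoned, and no measured step from a neighbouring pair is available. The expectation is therefore that compound 3 lies near compound 1, most likely again beyond the reach of the assay, with the step from compound 1 to compound 3 estimated as a step that the limit leaves unreadable from compound 1 to compound 3 and no clear direction beyond the scatter. Compound 3 is estimated at 50000 nM, within a range of 15000 nM to 160000 nM.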

Compound 3, half-maximal inhibitory concentration: > 40000 nM
Compound 3: only a limit was reported; the forecaster's own chance of this, stated with the estimate: 75%; the middle value is on the limit's open side.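

In this assay, compound 3 gives only a limit and not a number, as compound 1 does, so no step can be read between them, because both rest on the same limit: the limit of > 40000 nM in this assay, at which 2 of the 3 values shown sit.

The compounds shown leave open whether hydrogen in place of methoxy changes the antiproliferative activity at all, and in which direction.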